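The source may hold more compounds than are shown below. What is called first, only, known or untested is meant among the compounds shown, and "the series" means these compounds.

Of the compounds shown here, three built on one shared core have been tested in an assay on isolated protein for inhibition of tissue alpha-L-fucosidase (Bos taurus), tested at 1000 uM; a lower number here means less inhibition, a higher number more inhibition at the concentration tested (going by the name of the read-out). Compound 1 `COc1ccc([C@]2(CO)NC[C@@H](O)[C@@H]2O)cc1` gives 2.7% in this assay. Compound 2 `OC[C@]1(c2c(F)c(F)c(F)c(F)c2F)NC[C@H](O)[C@H]1O` gives 0%, and compound 3 `CCCC[C@]1(CO)NC[C@@H](O)[C@@H]1O` gives 20.8%. Compound 1 thus sits in the middle of the three numbers: its read-out and that of compound 2 lie within the usual scatter of each other, so they cannot be told apart, while compound 3 stands beyond the scatter above compound 1.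

The next compound, compound 4 `OC[C@@]1(c2ccccc2)NC[C@@H](O)[C@@H]1O`, has not yet been measured in this assay. It differs from compound 1 in one place: hydrogen in place of methoxy on an aromatic carbon. Because compound 1 gives 2.7% and compound 2, which also carries an aromatic ring on the core, gives 0%, little movement is expected from trimming the aromatic ring of compound 1. The step of a number 2.3 percentage points higher from compound 1 to compound 4 (within the scatter) is expected to stay within the scatter, in no clear direction. Compound 4 is therefore expected to give 5% in this assay, most likely between 0% and 15%.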

Compound 4, a percentage reported as inhibition, at one concentration (the size of the read-out at that concentration, not a potency): 0%
Compound 4: the middle estimate sits 5 percentage points above what was measured, within the range that was stated.
By their numbers in this assay, from the lowest: compounds 2, 4 and 1 (each within the scatter of the next); then compound 3.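

Going by these compounds alone, replacing methoxy with hydrogen on the aromatic ring is the first change in a single place that can be read in this assay, and the result is a number 2.7 percentage points lower from compound 1 to compound 4 (within the scatter). At this position, para to a group of 9 heavy atoms, methoxy can therefore be removed without a difference this read-out can distinguish, although both numbers lie so close to zero that it has little room to show any further drop. Nothing available here offers an explanation for this result.

Going by these compounds, it remains open whether an amine or a carboxylic acid at the same position would lift the number clear of the scatter. Also open, on these data alone, is whether a longer chain in place of methoxy would give a different result.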